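Notes on the step from compound 2 to compound 4

The source may hold more compounds than are shown below. What is called first, only, known or untested is meant among the compounds shown, and "the series" means these compounds.

Compound 1 `CC(=O)OC[C@H]1O[C@@H](n2cc(Cn3cc(/C=C4/C(=O)Nc5ccccc54)c4ccccc43)nn2)[C@H](OC(C)=O)[C@@H](OC(C)=O)[C@@H]1OC(C)=O` gives in a functional assay on HeLa cells (Homo sapiens) for cytotoxicity, read by sulforhodamine B assay, with a stated time of 48 h (on this read-out lower numbers stand for stronger inhibition and higher numbers for weaker inhibition), only a limit, > 200000 nM. Compound 2 `CC(=O)OC[C@H]1O[C@@H](n2cc(CN3C(=O)/C(=C\c4ccccc4)c4ccccc43)nn2)[C@H](OC(C)=O)[C@@H](OC(C)=O)[C@@H]1OC(C)=O` gives in this assay 33300 nM, and compound 3 `CC(=O)OC[C@H]1O[C@@H](n2cc(CN3C(=O)/C(=C/c4ccccc4)c4ccccc43)nn2)[C@H](OC(C)=O)[C@@H](OC(C)=O)[C@@H]1OC(C)=O` gives 37100 nM. Of the two numbers shown, compound 2 has the lowest; its nearest neighbour is compound 3, with a 1.1-fold higher number from compound 2 to compound 3 (0.05 log units; within the scatter), a step that rests on the fact that compounds 2 and 3 differ only in the configuration as drawn and so concerns the drawn configuration of the double bond alone. The value of compound 1 is a limit (the limit of > 200000 nM in this assay, at which 1 of the 3 values shown sits) and belongs to a differently arranged compound.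

Compound 4 `COc1ccc(/C=C2\C(=O)N(Cc3cn([C@@H]4O[C@H](COC(C)=O)[C@@H](OC(C)=O)[C@H](OC(C)=O)[C@H]4OC(C)=O)nn3)c3ccccc32)cc1OC` is not yet measured. It differs from compound 2 by 3,4-dimethoxyphenyl in place of phenyl on a double-bonded chain carbon bound to a double-bonded ring carbon. No measured step touches this place: the one step shown stays within the scatter and changes nothing at the phenyl, while compound 1 supplies no number. There is thus no ground for expecting a step beyond the scatter in either direction in this assay. Compound 4 is therefore expected at 33000 nM, between 11000 nM and 100000 nM. This means an expected step of a 1.0-fold lower number from compound 2 to compound 4 (0.00 log units; within the scatter).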

Compound 4, half-maximal inhibitory concentration: 63400 nM
Compound 4: the middle estimate sits 1.9-fold (0.28 log units) below what was measured; measured number inside the range.
By their numbers in this assay, from the lowest: compounds 2, 3 and 4 (each within the scatter of the next). At a limit, above all of these: compound 1.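

For the compounds shown here, compound 4 gives the first readable step for a change at this place, on a double-bonded chain carbon bound to a double-bonded ring carbon: in this assay, 3,4-dimethoxyphenyl in place of phenyl gives a 1.9-fold higher number from compound 2 to compound 4 (0.28 log units; within the scatter). The earlier step, a 1.1-fold higher number from compound 2 to compound 3 (0.05 log units; within the scatter), concerned only the drawn configuration of the double bond, whereas this one shows that the aromatic group itself can be exchanged here without a step beyond the scatter. Nothing at hand bears on why this exchange gives this result.

Going by these compounds, it remains open whether an amine or a carboxylic acid carried by the phenyl at this place would give a step beyond the scatter. On these data alone, how 3,4-dimethoxyphenyl behaves with the other drawn configuration of the double bond is also open.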